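The compounds below may be only part of what the source reports. "The series", "measured", "known", "first", "only" and "open" are said of these compounds alone.

Compound 1 `COc1cc(/C=C/C(=O)C2=C(/C=C/c3ccc(O)c(OC)c3)NC(=O)NC2c2c(Cl)cccc2Cl)ccc1O` and compound 2 `COc1cc(/C=C/C(=O)C2=C(/C=C/c3ccc(O)c(OC)c3)NC(=S)NC2c2ccccc2)ccc1O` share the same core. In a functional assay, with a stated time of 20 min, tested at 20 uM (on this read-out lower numbers stand for a weaker effect and higher numbers for a stronger effect at the one concentration tested), compound 1 gives 33%, and in the same run compound 2 gives 36.6%; these two numbers lie within the usual scatter of each other, so compound 2 stands level with compound 1 on the two numbers shown. Compound 3 `COc1cc(/C=C/C(=O)C2=C(/C=C/c3ccc(O)c(OC)c3)NC(=S)NC2c2ccccc2O)ccc1O` differs from compound 2 by hydroxy in place of hydrogen on an aromatic carbon. Going by the values given here, no measured pair carries this change, so no step beyond the scatter is expected in either direction. Compound 3 is expected to give about 37%, within 20% to 55%, in this assay. The expected step is a number 0.4 percentage points higher from compound 2 to compound 3 (within the scatter).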

Compound 3, a percentage reported as activity, at one concentration (the size of the read-out at that concentration, not a potency): 79.9%
The estimate for compound 3 lay 42.9 percentage points below the measured number; measured number above the stated range.
By their numbers in this assay, from the lowest: compounds 1 and 2 (each within the scatter of the next); then compound 3.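

Hydroxy in place of hydrogen, ortho to a large group on the six-membered aromatic ring, gives in this assay a number 43.3 percentage points higher from compound 2 to compound 3 (beyond the scatter) and is the first step in the series to clear the scatter. Going by these compounds alone, the read-out at this position therefore responds strongly to one added oxygen, which the two earlier compounds, level with each other and with no step at this place, could not show.

As far as these compounds go, whether a methoxy group, an amine or a carboxylic acid at the same position would keep this gain stays open. No measurement shown accounts for the step.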